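Replacing the oxazole with a carboxyphenyl group

The source may report more compounds than this note shows. Statements on the series, on what has been measured and on what is new or still open speak of the compounds shown alone.

Compound 1, `Clc1cc(Cl)cc(CO[C@H]2CCCN(Cc3ncco3)[C@H]2c2ccccc2)c1`, reaches only the limit > 200000 nM in an assay on isolated protein for activation of cGMP-dependent protein kinase 1 (Homo sapiens), read by ADP-Glo, with stated times of 120 min and 40 min; a higher number here means that more compound is needed for the effect, a lower number that less compound is needed.
Compound 2, `COc1cc(C(=O)O)ccc1CN1CCC[C@H](OCc2cc(Cl)cc(Cl)c2)[C@@H]1c1ccccc1`, gives 62000 nM in this assay.
Compound 3, `O=C(O)c1ccc2c(CN3CCC[C@H](O[C@H](CO)c4cc(Cl)cc(Cl)c4)[C@@H]3c3ccccc3)c[nH]c2c1`, gives 22000 nM in this assay.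

Compound 1 stands at the limit of this assay, (the limit of > 200000 nM in this assay, at which 1 of the 3 values shown sits), so no number is known for it. Compound 4, `O=C(O)c1ccc(CN2CCC[C@H](OCc3cc(Cl)cc(Cl)c3)[C@@H]2c2ccccc2)cc1`, differs from compound 1 by 4-carboxyphenyl in place of 1,3-oxazol-2-yl on a saturated chain carbon bound to an amine nitrogen in a ring. Going by the values given here, the one measured step that bears on this change is an at least 3.2-fold lower number from compound 1 to compound 2 (0.50 log units; beyond the scatter), where 4-carboxy-2-methoxyphenyl entered at the same place. Compound 3 carries a different change and is not directly comparable. A step of similar size and direction is expected for compound 4 because of an at least 3.2-fold lower number from compound 1 to compound 2 (0.50 log units; beyond the scatter), that is an at least 3.3-fold lower number from compound 1 to compound 4 (0.52 log units; beyond the scatter). Compound 4 is therefore estimated to give about 60000 nM in this assay, between 20000 nM and 200000 nM.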

Compound 4, half-maximal effective concentration: 76000 nM
The estimate for compound 4 lay 1.3-fold (0.10 log units) below the measured number; measured number inside the range.
By their numbers in this assay, from the lowest: compound 3; then compounds 2 and 4 (each within the scatter of the next). At a limit, above all of these: compound 1.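

The 4-carboxyphenyl group alone, in place of 1,3-oxazol-2-yl, gives an at least 2.6-fold lower number from compound 1 to compound 4 (0.42 log units; beyond the scatter) in this assay. Hydrogen in place of methoxy on an aromatic carbon gives a 1.2-fold higher number from compound 2 to compound 4 (0.09 log units; within the scatter), so the methoxy of compound 2 is not needed for this change to show. The full size of the first step stays unknown, as compound 1 stands at a limit: the limit of > 200000 nM in this assay, at which 1 of the 4 values shown sits.

From the compounds shown here alone, whether an amide or a methyl ester in place of the carboxylic acid would hold the number of compound 4 stays open. So does the effect of a longer chain between the amine nitrogen and the phenyl ring.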